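Isobutyl to propyl: a small expected change

This account rests on a few compounds, and the source may have more. Where it says the series, first, only, none or still open, it means among the compounds named here.

Results so far in an ADME assay on a cell-free system (plasma, Mus musculus) for protein binding, using equilibrium dialysis, with a stated time of 5 h, tested at 10 uM; a higher number here means a larger unbound share of the compound, a lower number a smaller unbound share:
Compound 1 `CC[C@@H](c1ccc(C(=O)O)c(Oc2cccc(Cl)c2)c1F)N1CCC[C@H](n2cc(C)c(=O)[nH]c2=O)C1`: "not determined" (no result reported)
Compound 2 `CCC[C@@H](c1ccc(C(=O)O)c(Oc2cccc(Cl)c2)c1OC)N1CCC[C@H](n2cc(C)c(=O)[nH]c2=O)C1`: "not determined" (no result reported)
Compound 3 `Cc1cn([C@H]2CCCN([C@@H](CC(C)C)c3ccc(C(=O)O)c(Oc4cccc(Cl)c4)c3F)C2)c(=O)[nH]c1=O`: 0.005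

Drugs in blood are partly held by plasma proteins, and the unbound fraction describes the share that stays free. Going by the values given here, compound 3 gives 0.005 in this assay and so has the only number available. Compounds 1 and 2 have no reported result, which leaves nothing to rank compound 3 against.

The next compound to be measured is compound 4 `CCC[C@@H](c1ccc(C(=O)O)c(Oc2cccc(Cl)c2)c1F)N1CCC[C@H](n2cc(C)c(=O)[nH]c2=O)C1`. It differs from compound 3 in one place: hydrogen in place of methyl on a saturated chain carbon bound to two saturated chain carbons. This puts hydrogen in place of methyl on a saturated chain carbon bound to two saturated chain carbons, turning isobutyl into propyl.

Among the compounds with values here, no measured pair shows what such a change does here, so the expectation is cautious. Starting from compound 3 at 0.005 in this assay, a small upward step is expected, with no move beyond the usual scatter. The estimate amounts to a 1.4-fold higher number from compound 3 to compound 4 (0.15 log units; within the scatter) and stays within that scatter. For compound 4 the estimated unbound fraction is 0.007 with an expected range from 0.004 to 0.013 in this measurement.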

Compound 4, unbound fraction: 0.007
Compound 4: the middle estimate sits on the measured number at the digits printed; the range from low to high includes it.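

In this assay the swap of isobutyl for propyl, which puts hydrogen in place of methyl on a saturated chain carbon bound to two saturated chain carbons, reads as a 1.4-fold higher number from compound 3 to compound 4 (0.15 log units; within the scatter) and leaves the two compounds indistinguishable in this measurement. Going by these compounds alone, this is the first pair in the set that differs in one place and has a number on both sides, so it gives the first direct reading at this position: this methyl can go without a shift that stands clear of repeat-to-repeat variation. The data offer no separate measurement that could explain this outcome.

Compounds 1 and 2 have no reported result, so any comparison with them cannot be read, and a single step within the scatter cannot show how the unbound fraction responds to larger changes at this position. On these data alone, whether a longer chain, or an amine or a hydroxyl group placed on the chain, would move the unbound fraction beyond the scatter remains open.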